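The source may hold more compounds than are shown below. What is called first, only, known or untested is meant among the compounds shown, and "the series" means these compounds.

Among the measured compounds shown here, in a toxicity assay on NIH3T3 cells (Mus musculus) for cytotoxicity, read by resazurin assay (a lower number here means that less compound is needed, a higher number that more compound is needed for the effect), no compound measured so far gives an exact number. Compound 1 `COC(=O)c1ccc(NCc2cncn2Cc2ccccc2)cc1-c1ccccc1` stands at > 1000 nM, which is a limit of the assay and not a number. Compound 2 `Cc1cccc(-c2cccc(NCc3cncn3Cc3ccccc3)c2)c1C` stands at > 1000 nM, which is also a limit. Compound 3 `COC(=O)c1ccc(NCc2cncn2Cc2ccc([N+](=O)[O-])cc2)cc1-c1ccccc1` stands at > 10000 nM, again a limit. As far as these compounds go, compound 2 is therefore known only by its limit, and its true value in this assay remains unknown.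

Compound 4 `Cc1cccc(-c2cccc(NCc3cncn3Cc3ccccc3)c2)c1` differs from compound 2 by one small edit (hydrogen in place of methyl on an aromatic carbon). Hydrogen takes the place of methyl on an aromatic carbon, so 2,3-dimethylphenyl becomes 3-methylphenyl.

For the measured compounds named here, only one measured step offers a comparison: a step that the two limits leave unreadable from compound 1 to compound 3. It is a different change, nitro in place of hydrogen on an aromatic carbon, and it gives no size to carry over. Going by the values given here, no measured pair tests the loss of this methyl, so no step beyond the usual scatter can be expected, in either direction.

The expectation rests on compound 2, at its limit of > 1000 nM. The expected change is a step that the limit leaves unreadable from compound 2 to compound 4. Compound 4 is estimated at 3000 nM, with an expected range from 1000 nM to 15000 nM, and the assay may well report only a limit again.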

Compound 4, half-maximal effective concentration: > 1000 nM
Compound 4 was reported as a limit; the forecaster's own chance of this, stated with the estimate: 85%; the middle value is on the limit's open side.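

Compound 2 and compound 4 are both known only by limits of the assay, so the step between them, hydrogen in place of methyl, cannot be read. The compounds shown leave open the true value of each one in this assay, and so whether this small edit changes that value at all.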